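This account rests on a few compounds, and the source may have more. Where it says the series, first, only, none or still open, it means among the compounds named here.

Compound 1, `O=C1c2ccccc2N(Cc2ccccc2Cl)S(=O)(=O)N1COCc1ccccc1`, and compound 2, `O=C1c2ccccc2N(Cc2ccccc2)S(=O)(=O)N1Cc1ccccc1Cl`, share one core; the chlorine-bearing benzyl sits on the ring nitrogen in compound 1 and on the amide-type nitrogen in compound 2. In a functional assay on HEL cells (Homo sapiens) (a higher number here means that more compound is tolerated, a lower number that less compound is tolerated), compound 1 gives 200000 nM, and in this assay compound 2 gives 200000 nM, so compound 2 stands level with compound 1 at the digits shown, within the usual scatter.

Compound 3, `O=C1c2ccccc2N(Cc2ccccc2)S(=O)(=O)N1COCc1ccccc1`, has not yet been measured. It differs from compound 2 by benzyloxy in place of 2-chlorophenyl on a saturated chain carbon bound to an amide-type nitrogen in a ring. The benzyloxy group that enters here is the same one that compound 1 carries, and compound 1 gives 200000 nM in this assay, while compound 2 gives 200000 nM. On that basis the expected step is no change at the digits printed from compound 2 to compound 3 (within the scatter), none beyond the scatter. Compound 3 is therefore estimated to give 200000 nM in this assay, with a range from 80000 nM to 300000 nM.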

Compound 3, minimum cytotoxic concentration: 49000 nM
Beside the measured number, compound 3's estimate is 4.1-fold (0.61 log units) above it, outside the stated range (below it).
By their numbers in this assay, from the lowest: compound 3; then compounds 1 and 2 (each within the scatter of the next).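

In this assay, going by these compounds alone, benzyloxy in place of 2-chlorophenyl on a saturated chain carbon bound to an amide-type nitrogen in a ring gives a 4.1-fold lower number from compound 2 to compound 3 (0.61 log units; beyond the scatter), so the number does respond to the group at this position, which the earlier compounds could not show. Hydrogen in place of chloro on an aromatic carbon gives a 4.1-fold lower number from compound 1 to compound 3 (0.61 log units; beyond the scatter), so in this assay the chlorine of compound 1 counts as well, and both steps are modest but beyond the scatter. No measurement is available that bears on why either step occurs.

The compounds shown leave open how this assay would respond to an amine or a longer chain at this position. They also leave open whether fluoro in place of chloro would give the same number as chloro or as hydrogen.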